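From Amide to Acid Among Limit Readings

The source may report more compounds than this note shows. Statements on the series, on what has been measured and on what is new or still open speak of the compounds shown alone.

In an ADME assay on microsomes from liver (Mus musculus) for metabolic stability, read by LC-MS, using NADPH, with a stated time of 30 min, tested at 0.1 uM, in the presence of a further agent that is not named here (a higher number here means that more of the compound is left, a lower number that less of the compound is left), compound 1 (`Nc1ccc(-c2cnc(N)c(-c3ccc(N)nc3)n2)cn1`) gives > 90% as a limit of the assay, not a number. Compound 3 (`N#Cc1ccc(-c2cnc(N)c(-c3ccc(N)nc3)n2)cc1`) gives > 90% as a limit too. Compound 2 (`NC(=O)c1ccc(-c2cnc(N)c(-c3ccc(C(F)(F)F)cc3)n2)cc1`) gives > 90% and so also has only a limit. Compound 2 therefore stands with the others on the limit of > 90% in this assay, at which 3 of the 3 values shown sit, and cannot be ranked against them.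

Compound 4 (`Nc1ncc(-c2ccc(C(=O)O)cc2)nc1-c1ccc(C(F)(F)F)cc1`) has not yet been measured. It differs from compound 2 by hydroxy in place of amino on a carbonyl carbon in the change of carbamoyl to carboxy, with hydroxy in place of amino on a carbonyl carbon. Among the measured compounds shown here, no step between measured compounds offers a guide, so the expectation rests on compound 2 with its > 90% as a limit. The estimated step that the limit leaves unreadable from compound 2 to compound 4 in this assay is expected to stay within the usual scatter. For compound 4 the estimated percent remaining is 92% with 78% to 100% as the expected range.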

Compound 4, percent of the compound remaining: > 90%
Compound 4: only a limit was reported; the forecaster's own chance of this, stated with the estimate: 55%; the middle value does not contradict the limit.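

No step can be read from compound 2 to compound 4 in this assay, as both compounds sit on the same limit, which is not a number: the limit of > 90% in this assay, at which 4 of the 4 values shown sit.

The compounds shown leave open whether carbamoyl and carboxy differ at all in percent remaining, and how compound 1, compound 2, compound 3 and compound 4 rank.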